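Compound 2 and the change that leads to compound 3

The source may report more compounds than this note shows. Statements on the series, on what has been measured and on what is new or still open speak of the compounds shown alone.

Two compounds have so far been examined in a functional assay on the whole organism with Rattus norvegicus as the target; on this read-out lower numbers stand for an effect already at smaller amounts and higher numbers for an effect only at larger amounts of compound. For the measured compounds named here, compound 1, `CCCCCCCc1ccc2nc(N)sc2c1`, and compound 2, `COC(=O)Cn1c(=N)sc2cc(OC(F)(F)F)ccc21`, share the same fused core but differ in several places, so no single step between them can be read. In this assay compound 1 gave only a limit, > 10 mg/kg. In this assay compound 2 also gave only a limit, > 10 mg/kg. Compound 2 therefore stands at the limit of > 10 mg/kg in this assay, at which 2 of the 2 values shown sit, and no measured difference separates it from compound 1.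

Compound 3, `C[S+]([O-])Cn1c(=N)sc2cc(OC(F)(F)F)ccc21`, is the next compound to be measured in this assay. It differs from compound 2 by a group of 3 heavy atoms (1 carbon, 1 oxygen, 1 sulfur; no ring) in place of a group of 4 heavy atoms (2 carbon, 2 oxygen; no ring), on a saturated chain carbon bound to an aromatic nitrogen. Going by the values given here, no step between measured compounds is available to guide the size of the change, and nothing in the measured values points in either direction. Compound 3 is expected to give about 15 mg/kg, within a range from 5 mg/kg to 50 mg/kg, most likely again as a limit. The expected step from compound 2 to compound 3 is a step that the limit leaves unreadable from compound 2 to compound 3, that is, nothing beyond the scatter.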

Compound 3, dose for half-maximal effect: 2.3 mg/kg
The estimate for compound 3 lay 6.5-fold (0.81 log units) above the measured number, outside the stated range (below it).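

In this assay, replacing the methoxycarbonyl group with the group of 3 heavy atoms (1 carbon, 1 oxygen, 1 sulfur; no ring), on a saturated chain carbon bound to an aromatic nitrogen, gives an at least 4.3-fold lower number from compound 2 to compound 3 (0.63 log units; beyond the scatter). For the compounds shown here, this is the first readable step, and it shows that the read-out responds to a change at this place, which compound 1 and compound 2 could not show between them. Compound 2 remains a limit, so the step has a lower bound but no exact size, and compound 3 stands apart as the only compound with a measured number: the limit of > 10 mg/kg in this assay, at which 2 of the 3 values shown sit.

Going by these compounds alone, the single step cannot separate the loss of the methoxycarbonyl group from the arrival of the sulfur-containing group, and it does not show whether a carboxylic acid, an amine or a longer chain at this place would give a number like that of compound 3. Going by these compounds, because compound 2 and compound 3 share the trifluoromethoxy group, it also remains open whether the step would hold with another group there, such as the heptyl chain of compound 1.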